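A few compounds are considered here, and "the series" means these few. Any claim that something is new, unique, unknown or untested is made for them only; others in the source may bear on it.

Compound 1 `CCCc1cc(N)c2cc(NC(=O)/C=C/c3ccc(N)cc3)ccc2n1` holds the lowest of the two numbers in an assay on isolated protein for displacement of a labelled ligand from melanin-concentrating hormone receptor 1 (Homo sapiens) (a lower number here means a stronger inhibitor, a higher number a weaker inhibitor), where compound 1 gives 190 nM. In this assay compound 2 `CCCc1cc(N)c2cc(NC(=O)c3ccc(C(F)(F)F)cc3)ccc2n1` gives 10000 nM, a far higher number, beyond the usual scatter. Compound 3 `CCCc1cc(N)c2cc(NC(=O)/C=C/c3ccc(Br)cc3)ccc2n1` differs from compound 1 by bromo in place of amino on an aromatic carbon: a bromo in place of an amino on an aromatic carbon of a six-membered aromatic ring of carbon only, para to a large group. Going by the values given here, no measured pair shows this single change, and compound 2 differs from compound 1 in more than one place. A moderate weakening is expected, a step of a 5.3-fold higher number from compound 1 to compound 3 (0.72 log units; beyond the scatter). Compound 3 is expected to give 1000 nM, within 200 nM to 6000 nM.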

Compound 3, half-maximal inhibitory concentration: 4 nM
Compound 3: middle estimate off by 250-fold (2.40 log units), on the high side; the measured number lies below the stated range.
By their numbers in this assay, from the lowest: compound 3; then compound 1; then compound 2.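

Replacing amino with bromo on the 4-aminophenyl ring gives a 48-fold lower number from compound 1 to compound 3 (1.68 log units; beyond the scatter) in this assay, so this single atom change at this position has a large effect on the number. The amino group counts a hydrogen-bond donor and acceptor and the bromo neither, so neither is needed here for a low number. No measurement at hand accounts for the size of this step. Open, on these data alone, is whether this gain is specific to bromo, or whether chloro, iodo, methyl or a plain hydrogen at the same place would give a similarly low number.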